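Phenyl on the ring nitrogen of compound 3

The source may report more compounds than this note shows. Statements on the series, on what has been measured and on what is new or still open speak of the compounds shown alone.

In an ADME assay on Vero cells (Chlorocebus sabaeus) for antiproliferative activity, read by MTT assay (a lower number here means a stronger inhibitor, a higher number a weaker inhibitor), the measured compounds stand as follows
compound 1 `Fc1ccc(N2CCN(c3nc(-n4ccc5ccccc54)c4ccccc4n3)CC2)cc1`: 50 ug/mL
compound 2 `COc1ccc(-c2nc(N3CCNCC3)nc3ccccc23)c(OC)c1`: 50 ug/mL
compound 3 `c1ccc2c(c1)ccn2-c1nc(N2CCNCC2)nc2ccccc12`: 8.9 ug/mL

Compound 3 has the lowest number of the three, and the gaps to compound 1 and compound 2 both lie beyond the scatter. Compound 4 `c1ccc(N2CCN(c3nc(-n4ccc5ccccc54)c4ccccc4n3)CC2)cc1` carries phenyl in place of hydrogen on an amine nitrogen in a ring. Among the measured compounds shown here, one measured step bears on this: a 5.6-fold lower number from compound 1 to compound 3 (0.75 log units; beyond the scatter), where hydrogen replaced 4-fluorophenyl at that same nitrogen. The present change runs the opposite way, so a step of similar size toward a higher number is expected, which would mean a weaker result. The expected step is a 4.5-fold higher number from compound 3 to compound 4 (0.65 log units; beyond the scatter), as estimated from that single precedent. For compound 4 the estimated value is 40 ug/mL, with an expected range from 20 ug/mL to 80 ug/mL.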

Compound 4, half-maximal inhibitory concentration: 50 ug/mL
The estimate for compound 4 lay 1.3-fold (0.10 log units) below the measured number; measured number inside the range.
By their numbers in this assay, from the lowest: compound 3; then compounds 1, 2 and 4 (each within the scatter of the next).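

In this assay, phenyl on the amine nitrogen in the ring gives a 5.6-fold higher number from compound 3 to compound 4 (0.75 log units; beyond the scatter), a step the same size as the one seen with 4-fluorophenyl at that nitrogen. Hydrogen in place of fluoro on the aromatic carbon gives no change at the digits printed from compound 1 to compound 4 (within the scatter), so the fluoro has no readable effect in this pair. Nothing measured here explains these steps. The compounds shown leave open how a methyl or an acetyl on that nitrogen would compare, since only hydrogen and the two aryl groups appear there.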